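This account rests on a few compounds, and the source may have more. Where it says the series, first, only, none or still open, it means among the compounds named here.

In an assay for inhibition of Amine oxidase [flavin-containing] B (Rattus norvegicus) (a lower number here means a stronger inhibitor, a higher number a weaker inhibitor), compound 2 `NC(=O)[C@@H]1CCCN1Cc1cc(=O)oc2cc(OCc3ccccc3)ccc12` gives 380 nM, the lowest of the three numbers measured. Compound 1 `C[C@H](Nc1cc(=O)oc2cc(OCc3ccccc3)ccc12)C(N)=O` gives 680 nM in this assay, and compound 3 `NC(=O)[C@@H]1CCCN1Cc1cc(=O)oc2cc(OCc3cccc(F)c3)ccc12` gives 850 nM. The step of a 1.8-fold lower number from compound 1 to compound 2 (0.25 log units; within the scatter) stays within the scatter, whereas the step of a 2.2-fold higher number from compound 2 to compound 3 (0.35 log units; beyond the scatter) goes modestly beyond it. Compound 4 `CC(C(N)=O)c1cc(=O)oc2cc(OCc3ccccc3)ccc12` has not yet been measured; it differs from compound 2 in one place: 1-carbamoylethyl in place of (2-carbamoylpyrrolidin-1-yl)methyl on an aromatic carbon. Of the measured steps, a 1.8-fold lower number from compound 1 to compound 2 (0.25 log units; within the scatter) bears most on this change, because a 1.8-fold lower number from compound 1 to compound 2 (0.25 log units; within the scatter) likewise set a carbamoylethyl unit against the ring-bearing one and stayed within the scatter, so for compound 4 little or only a modest rise in the number is expected. Compound 4 is therefore expected to give 700 nM in this assay, within 250 nM to 2000 nM. This estimate corresponds to an expected step of a 1.8-fold higher number from compound 2 to compound 4 (0.27 log units; within the scatter).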

Compound 4, half-maximal inhibitory concentration: 100 nM
Beside the measured number, compound 4's estimate is 7.0-fold (0.85 log units) above it; measured number outside the range, below it.
By their numbers in this assay, from the lowest: compound 4; then compounds 2, 1 and 3 (each within the scatter of the next, the first and the last beyond it).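

Among these compounds, at the position opposite the ring oxygen, the group matters more than the earlier compounds showed in this assay: 1-carbamoylethyl, which has no ring, gives a 3.8-fold lower number from compound 2 to compound 4 (0.58 log units; beyond the scatter) and also a 6.8-fold lower number from compound 1 to compound 4 (0.83 log units; beyond the scatter). The second step shows that a low number here does not need the amino link of compound 1. No evidence is available to explain either step. As far as these compounds go, it remains open whether a shorter chain such as carbamoylmethyl, or a carboxylic acid in place of the amide, would hold the number this low. From the compounds shown here alone, whether the fluoro change would act the same way on compound 4 is also open.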